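Amine swap on the methoxy core: expected potency

This account rests on a few compounds, and the source may have more. Where it says the series, first, only, none or still open, it means among the compounds named here.

Three members of the series have numbers in an assay on isolated protein for inhibition of NADPH oxidase 2 (Homo sapiens), read by chemiluminescence, in the presence of a further agent that is not named here; on this read-out lower numbers stand for stronger inhibition and higher numbers for weaker inhibition. Compound 1 `CCN(CC)c1ccc(/C=C2\C(=O)N(C3CCCCC3)C(=S)N2C)cc1` gives 5660 nM in this assay. Compound 2 `CN1C(=S)N(C2CCCCC2)C(=O)/C1=C\c1ccc(N(C)CCCO)cc1` gives 2400 nM in this assay. Compound 3 `CCN(CC)c1ccc(/C=C2\C(=O)N(C3CCCCC3)C(=S)N2C)c(OC)c1` gives 1950 nM in this assay. The change (3-hydroxypropyl)(methyl)amino in place of diethylamino on an aromatic carbon made the step of a 2.4-fold lower number from compound 1 to compound 2 (0.37 log units; beyond the scatter). The cores of compound 1 and compound 3 differ by methoxy in place of hydrogen on an aromatic carbon, which made the step of a 2.9-fold lower number from compound 1 to compound 3 (0.46 log units; beyond the scatter). Compound 3 has the lowest number of the three, but its gap to compound 2 is within the scatter, so no order between those two is claimed.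

Compound 4 `COc1cc(N(C)CCCO)ccc1/C=C1\C(=O)N(C2CCCCC2)C(=S)N1C` is not yet measured. It differs from compound 3 by (3-hydroxypropyl)(methyl)amino in place of diethylamino on an aromatic carbon. This is the same kind of change as (3-hydroxypropyl)(methyl)amino in place of diethylamino on an aromatic carbon, but the place is not identical: in compound 3 the amine sits meta to a methoxy group, which is absent in compound 1. From the compounds shown here alone, the step from compound 3 to compound 4 in this assay is expected to be a 2.2-fold lower number from compound 3 to compound 4 (0.34 log units; beyond the scatter), about the size of the earlier step, because a 2.4-fold lower number from compound 1 to compound 2 (0.37 log units; beyond the scatter) was beyond the scatter; whether it carries over to the core of compound 3 is unknown, so the range is kept wide. Compound 4 is expected at 900 nM in this assay, between 400 nM and 2000 nM.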

Compound 4, half-maximal inhibitory concentration: 990 nM
Beside the measured number, compound 4's estimate is 1.1-fold (0.04 log units) below it; measured number inside the range.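

In this assay, the amine swap on the methoxy core gives a 2.0-fold lower number from compound 3 to compound 4 (0.29 log units; within the scatter), and adding methoxy to the core of compound 2 gives a 2.4-fold lower number from compound 2 to compound 4 (0.38 log units; beyond the scatter). The swap of diethylamino for (3-hydroxypropyl)(methyl)amino is of similar size on both cores, although on the methoxy core its step alone cannot be told from the scatter: the same change on two cores in this assay, a 2.4-fold lower number (0.37 log units; beyond the scatter) from compound 1 to compound 2 and a 2.0-fold lower number (0.29 log units; within the scatter) from compound 3 to compound 4, 1.2-fold (0.08 log units) apart, within the scatter of two such steps The methoxy step is also of similar size on both cores, so the two changes behave as independent within these four compounds, but this single set of four shows no general rule for other cores or substituents: the same change on two cores in this assay, a 2.9-fold lower number (0.46 log units; beyond the scatter) from compound 1 to compound 3 and a 2.4-fold lower number (0.38 log units; beyond the scatter) from compound 2 to compound 4, 1.2-fold (0.08 log units) apart, within the scatter of two such steps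

From the compounds shown here alone, whether this holds for a longer hydroxyalkyl chain, a cyclic amine such as morpholine, or a carboxylic acid at the chain end stays open. Groups such as ethoxy or fluorine in place of methoxy also remain to be tested against the same amine swap.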